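The source may report more compounds than this note shows. Statements on the series, on what has been measured and on what is new or still open speak of the compounds shown alone.

Measured compounds:
- Compound 1, `CC1=C(C(=O)Nc2ccc(Cl)c(Cl)c2)C(c2cccc(O)c2)NC(=S)N1`: 14100 nM
- Compound 2, `CC1=C(C(=O)Nc2ccc(F)c(Cl)c2)C(c2cccc(Cl)c2)NC(=S)N1`: 25100 nM
- Compound 3, `CC1=C(C(=O)Nc2ccc(F)c(Cl)c2)C(c2ccccc2Cl)NC(=S)N1`: 20400 nM

All three were tested in a functional assay on PC-3 cells (Homo sapiens) for cytotoxicity, read by sulforhodamine B assay, with a stated time of 48 h; on this read-out lower numbers stand for stronger inhibition of growth and higher numbers for weaker inhibition of growth. Compound 3 gives the second highest of the three numbers. Among the measured compounds shown here, its nearest neighbour is compound 2, and the only single-point step recorded here, a 1.2-fold lower number from compound 2 to compound 3 (0.09 log units; within the scatter), is too small to count. Compound 1 lies a little further off, but that gap too is within the scatter, so the three compounds cannot be told apart on these figures.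

Compound 4, `CC1=C(C(=O)Nc2ccc(Cl)c(Cl)c2)C(c2ccccc2Cl)NC(=S)N1`, is not yet measured. It differs from compound 3 in one place: chloro in place of fluoro on an aromatic carbon. The anilide ring thus becomes 3,4-dichlorophenyl instead of 3-chloro-4-fluorophenyl. For the measured compounds named here, no measured pair isolates exactly this swap; compound 1 carries the 3,4-dichlorophenyl anilide but also a different group on the saturated ring carbon, so its value only shows that such compounds stay in the same broad region. The expectation is therefore for no change beyond the scatter, a 1.2-fold lower number from compound 3 to compound 4 (0.08 log units; within the scatter), with compound 4 estimated at 17000 nM (range 7000 nM to 45000 nM).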

Compound 4, concentration for 50% growth inhibition: 20000 nM
For compound 4 the middle estimate is 1.2-fold (0.07 log units) below the measured one; measured number inside the range.
By their numbers in this assay, from the lowest: compounds 1, 4, 3 and 2 (each within the scatter of the next).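

In this assay the swap of fluoro for chloro, on the aromatic carbon para to a large group and ortho to a chloro group, now has a direct pair, and it produces no readable shift (a 1.0-fold lower number from compound 3 to compound 4 (0.01 log units; within the scatter)). So 3-chloro-4-fluorophenyl and 3,4-dichlorophenyl cannot be told apart here when the saturated ring carbon carries 2-chlorophenyl, and with the 3,4-dichlorophenyl anilide held fixed, that 2-chlorophenyl and a 3-hydroxyphenyl cannot be told apart either (a 1.4-fold higher number from compound 1 to compound 4 (0.15 log units; within the scatter)). No independent measurement is available to explain either result.

Still open, on these data alone, is whether a group other than a halogen at the same aromatic carbon, such as a methoxy group or an amine, would move the number beyond the scatter. The same question holds for a carboxylic acid on the phenyl ring at the saturated ring carbon.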